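The source may report more compounds than this note shows. Statements on the series, on what has been measured and on what is new or still open speak of the compounds shown alone.

Among the measured compounds shown here, compound 2 `COc1ccc(N(C)c2ccnc(Cl)n2)cc1OCCCCCBr` gives 9720 nM in a functional assay on A549 cells (Homo sapiens) for antiproliferative activity, read by MTT assay, with a stated time of 48 h (a higher number here means a weaker inhibitor, a lower number a stronger inhibitor), the highest of the two numbers known so far, while compound 1 `COc1ccc(N(C)c2ccnc(Cl)n2)cc1OCCCBr` gives 862 nM. For the measured compounds named here, the only measured step, an 11-fold higher number from compound 1 to compound 2 (1.05 log units; beyond the scatter), altered the chain but left the end group alone, so it bears only loosely on compound 3 `COc1ccc(N(C)c2ccnc(Cl)n2)cc1OCCCC[Se]C#N`, which differs from compound 2 by a group of 3 heavy atoms (1 carbon, 1 nitrogen, 1 selenium; no ring) in place of a group of 2 heavy atoms (1 carbon, 1 bromine; no ring), on a saturated chain carbon, four bonds along the chain from an oxygen on an aromatic ring. Without a direct precedent for this change, only a modest step, a 2.4-fold lower number from compound 2 to compound 3 (0.39 log units; beyond the scatter), is expected, with wide uncertainty in either direction. Compound 3 is therefore estimated at 4000 nM, within a range from 900 nM to 15000 nM.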

Compound 3, half-maximal inhibitory concentration: > 10000 nM
Compound 3 was reported as a limit; the forecaster's own chance of this, stated with the estimate: 5%; at least 2.5-fold (0.39 log units) between middle value and limit.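

In this assay compound 3 is reported only as a limit: the limit of > 10000 nM in this assay, at which 1 of the 3 values shown sits. Replacing bromomethyl with the selenium-bearing nitrile group gives an at least 1.0-fold higher number from compound 2 to compound 3 (0.01 log units; that floor lies within the scatter), so at this saturated chain carbon the change shows no gain in potency, although that floor cannot show a real loss. The wider comparison is firmer, with an at least 11-fold higher number from compound 1 to compound 3 (1.06 log units; beyond the scatter), a large step that still combines the change at the chain end with a different chain.

From the compounds shown here alone, how the selenium-bearing nitrile group would act on a shorter chain remains open. So does the effect of an amine or a carboxylic acid at this chain end.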